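The compounds below may be only part of what the source reports. "The series", "measured", "known", "first", "only" and "open" are said of these compounds alone.

Series notes on a functional assay on the whole organism with Rattus norvegicus as the target; a lower number here means that less compound is needed, a higher number that more compound is needed for the effect. Of the compounds shown here, three have a number so far. Compound 1 `Nc1ncnc2nc(-c3ccc(N4CCC[C@H]4CO)nn3)cc(-c3cccc(Br)c3)c12` gives 10 umol/kg in this assay. Compound 2 `Nc1ncnc2nc(-c3ccc(N4CCC(COC5CCOCC5)CC4)nn3)cc(-c3cccc(Br)c3)c12` gives 5 umol/kg, and compound 3 `Nc1ncnc2nc(-c3ccc(N4CCC(=NOC5CCOCC5)CC4)nn3)cc(-c3cccc(Br)c3)c12` gives 2 umol/kg. Compound 1 thus holds the highest of the three numbers; its gap to compound 2 falls within the usual scatter, so no order between those two can be claimed, whereas the gap to compound 3 lies beyond the scatter. Both compound 2 and compound 3 carry a six-membered non-aromatic ring with 1 hetero atom at the position where compound 1 carries the 2-(hydroxymethyl)pyrrolidin-1-yl group.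

Compound 4 `COCCOC1CCN(c2ccc(-c3cc(-c4cccc(Br)c4)c4c(N)ncnc4n3)nn2)CC1` has not yet been measured. Against compound 1 the change is 4-(2-methoxyethoxy)piperidin-1-yl in place of 2-(hydroxymethyl)pyrrolidin-1-yl on an aromatic carbon. The five-membered non-aromatic ring of compound 1 gives way to the six-membered non-aromatic ring type seen in compound 2 and compound 3, here carrying 2-methoxyethoxy.

Going by the values given here, no measured pair isolates this change, so the expectation rests on the numbers of compound 2 and compound 3. The step of a 2.0-fold lower number from compound 1 to compound 4 (0.30 log units; within the scatter) is expected to run toward a lower number and to be moderate, possibly not beyond the scatter. Compound 4 is expected to give 5 umol/kg, with a range from 2 umol/kg to 12 umol/kg.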

Compound 4, dose for half-maximal effect: 3 umol/kg
The estimate for compound 4 lay 1.7-fold (0.22 log units) above the measured number; the measured number falls inside the stated range.
By their numbers in this assay, from the lowest: compounds 3, 4, 2 and 1 (each within the scatter of the next, the first and the last beyond it).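

In this assay, going by these compounds alone, 4-(2-methoxyethoxy)piperidin-1-yl in place of 2-(hydroxymethyl)pyrrolidin-1-yl on the aromatic carbon gives a 3.3-fold lower number from compound 1 to compound 4 (0.52 log units; beyond the scatter), the first directly readable step at this position, and it lies beyond the scatter. A second step shows that the substituent on the six-membered ring can be simplified without a change that can be told apart: 2-methoxyethoxy in place of ((oxan-4-yl)oxy)methyl gives a 1.7-fold lower number from compound 2 to compound 4 (0.22 log units; within the scatter), so the oxan-4-yl ring is not required to keep the number at this level. The step away from 2-(hydroxymethyl)pyrrolidin-1-yl changes the ring size, the hydrogen-bond donor count, the defined stereocentre and the heavy-atom count all at once, and no available data explain the shift.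

The compounds shown do not separate the contribution of the six-membered ring from that of the 2-methoxyethoxy chain; a plain piperidin-1-yl group, or a pyrrolidin-1-yl ring carrying 2-methoxyethoxy, would address that. As far as these compounds go, the response of this position to a 4-aminopiperidin-1-yl group, a longer chain such as 3-methoxypropoxy or a carboxylic acid at the chain end also remains open.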